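The compounds below may be only part of what the source reports. "The series", "measured", "known", "first", "only" and "open" are said of these compounds alone.

In a functional assay on PC-3 cells (Homo sapiens) for antiproliferative activity, read by MTT assay, with a stated time of 24 h (a lower number here means a stronger inhibitor, a higher number a weaker inhibitor), compound 1 (`CCn1c(C(=O)N[C@H](CO)CCCO)ccc1C(CC)(CC)c1ccc(OCS(=O)(=O)c2ccccc2)c(C)c1`) gives 6810 nM, compound 2 (`CCn1c(C(=O)NCC(=O)O)ccc1C(CC)(CC)c1ccc(OCS(=O)(=O)c2ccccc2)c(C)c1`) gives 30100 nM and compound 3 (`CCn1c(C(=O)NC2(C(=O)O)CC2)ccc1C(CC)(CC)c1ccc(OCS(=O)(=O)c2ccccc2)c(C)c1`) gives 26300 nM. Compound 3 thus stands level with compound 2 and apart from compound 1. The two steps that bear on this are modest: a 4.4-fold higher number from compound 1 to compound 2 (0.65 log units; beyond the scatter), and a 3.9-fold higher number from compound 1 to compound 3 (0.59 log units; beyond the scatter). Exchanging carboxymethyl for 1-carboxycyclopropyl shifts nothing measurable: a 1.1-fold lower number from compound 2 to compound 3 (0.06 log units; within the scatter). Compound 4 (`CCn1c(C(=O)N[C@H](CC(=O)O)C(=O)O)ccc1C(CC)(CC)c1ccc(OCS(=O)(=O)c2ccccc2)c(C)c1`) brings (1,2-dicarboxyethyl in place of 1-carboxycyclopropyl on an amide-type nitrogen), that is, 1,2-dicarboxyethyl in place of 1-carboxycyclopropyl on an amide-type nitrogen. Among the compounds with values here, no measured compound carries this group, so the expectation rests on the closest pair alone: no shift beyond the scatter in this assay, and no firm direction. The expected step is a 1.1-fold higher number from compound 3 to compound 4 (0.06 log units; within the scatter). Compound 4 is estimated at 30000 nM, with an expected range of 14000 nM to 65000 nM.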

Compound 4, half-maximal inhibitory concentration: > 50000 nM
Compound 4: no number, only a limit (the forecaster's own chance of this, stated with the estimate: 15%); middle value at least 1.6-fold (0.22 log units) away from the limit.
By their numbers in this assay, from the lowest: compound 1; then compounds 3 and 2 (each within the scatter of the next). At a limit, above all of these: compound 4.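

In this assay compound 4 gives no number, only a limit: the limit of > 50000 nM in this assay, at which 1 of the 4 values shown sits.

Adding carboxymethyl on the saturated chain carbon gives an at least 1.6-fold higher number from compound 2 to compound 4 (0.22 log units; that floor lies within the scatter), and the exchange of 1-carboxycyclopropyl for 1,2-dicarboxyethyl gives an at least 1.9-fold higher number from compound 3 to compound 4 (0.27 log units; that floor lies within the scatter), so neither step is shown to exceed the scatter. Within the data shown here, the one step that clears it is an at least 7.3-fold higher number from compound 1 to compound 4 (0.86 log units; beyond the scatter), so a second carboxylic acid on this amide-type nitrogen does not bring the number back towards compound 1.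

Open, as far as these compounds go, is how far past its limit compound 4 lies, and whether a methyl ester or primary amide in place of the carboxylic acid would move the number towards compound 1.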